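The source may hold more compounds than are shown below. What is called first, only, known or untested is meant among the compounds shown, and "the series" means these compounds.

Series notes. In a functional assay on IMR-32 cells with melanin-concentrating hormone receptor 1 (Homo sapiens) as the target, read by fluorescence (on this read-out lower numbers stand for stronger inhibition and higher numbers for weaker inhibition), compound 1 `COc1cccc(C(=O)NCCCOc2cccc3ccc(N)nc23)c1` gives 30 nM. Compound 2 `N#Cc1cccc(C(=O)NCCCOc2cccc3ccc(N)nc23)c1` gives 7 nM in this assay, and compound 3 `Nc1ccc2cccc(OCCCNC(=O)c3cccc(Cl)c3)c2n1` gives 3 nM. The three differ only in the group on one aromatic carbon of a six-membered aromatic ring of carbon only: a 4.3-fold lower number from compound 1 to compound 2 (0.63 log units; beyond the scatter), a 10-fold lower number from compound 1 to compound 3 (1.00 log units; beyond the scatter), and a 2.3-fold lower number from compound 2 to compound 3 (0.37 log units; beyond the scatter). Compound 3 therefore stands at the lowest number of the three, with compound 2 nearest and compound 1 furthest.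

Compound 4 `Nc1ccc2cccc(OCCCNC(=O)c3cccc(OC(F)(F)F)c3)c2n1` changes that same carbon once more: trifluoromethoxy in place of chloro on an aromatic carbon. Within the data shown here, no measured step involves the trifluoromethoxy group, so the three steps above are the only guide; they show that exchanging the group on this carbon shifts the number over a modest span, with chloro at the low end. An exchange of chloro for a group without precedent in this set is expected to give a modest move toward a higher number in this assay, or none beyond the scatter, and the step from compound 3 to compound 4 is estimated as a 2.0-fold higher number from compound 3 to compound 4 (0.30 log units; within the scatter). Compound 4 is expected to give 6 nM, within 2 nM to 20 nM.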

Compound 4, half-maximal inhibitory concentration: 20 nM
Estimate against measurement, compound 4: 3.3-fold (0.52 log units) below, within the range that was stated.
By their numbers in this assay, from the lowest: compound 3; then compound 2; then compounds 4 and 1 (each within the scatter of the next).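

In this assay the trifluoromethoxy group on this aromatic carbon loses most of the advantage seen with chloro, with a 6.7-fold higher number from compound 3 to compound 4 (0.82 log units; beyond the scatter), and it also falls short of the cyano group, with a 2.9-fold higher number from compound 2 to compound 4 (0.46 log units; beyond the scatter). Trifluoromethyl in place of methyl on the oxygen gives a 1.5-fold lower number from compound 1 to compound 4 (0.18 log units; within the scatter), so the fluorines make no difference beyond the scatter, and compound 1 and compound 4 together form the high end of the four, leaving chloro and cyano as the two groups that stand apart at the low end. Nothing measured here bears on the reason for these steps.

Open, on these data alone, is whether a fluoro or bromo group, or an amine, on this carbon would match chloro. As far as these compounds go, whether the order of these groups holds with a longer chain on the shared core also remains open.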